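Phenyl in place of pyridinylmethyl on the piperazine nitrogen

The compounds below may be only part of what the source reports. "The series", "measured", "known", "first", "only" and "open" are said of these compounds alone.

The shared core is a propyl-linked piperazine on a triazolyl-substituted indole. In an assay on CHO cells for displacement of a labelled ligand from 5-hydroxytryptamine receptor 1B (Homo sapiens) (on this read-out lower numbers stand for stronger inhibition and higher numbers for weaker inhibition), compound 1 `c1cc(CN2CCN(CCCc3c[nH]c4ccc(-n5cnnc5)cc34)CC2)ccn1` gives 23 nM, the second highest of the three numbers measured. Compound 2 `c1coc(CN2CCN(CCCc3c[nH]c4ccc(-n5cnnc5)cc34)CC2)c1`, carrying a furan-2-ylmethyl group instead, gives 18 nM; the step of a 1.3-fold lower number from compound 1 to compound 2 (0.11 log units; within the scatter). Compound 3 `c1cc2[nH]cc(CCCN3CCNCC3)c2cc1-n1cnnc1`, with a bare ring nitrogen, gives 145 nM; the steps of a 6.3-fold higher number from compound 1 to compound 3 (0.80 log units; beyond the scatter) and an 8.1-fold higher number from compound 2 to compound 3 (0.91 log units; beyond the scatter).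

Compound 4 `c1ccc(N2CCN(CCCc3c[nH]c4ccc(-n5cnnc5)cc34)CC2)cc1` differs from compound 1 in one place: phenyl in place of (pyridin-4-yl)methyl on an amine nitrogen in a ring. Two things in the measured steps bear on this. First, exchanging one arylmethyl group for another, as from compound 1 to compound 2, changed nothing beyond the scatter. Second, removing the arylmethyl group altogether, as in compound 3, raised the number by a modest amount. Among the compounds with values here, a phenyl bound directly to the ring nitrogen keeps an aromatic ring there but drops the chain carbon, a change none of the measured steps covers exactly. On this basis compound 4 is expected to stay close to compound 1, with the step of a 1.0-fold lower number from compound 1 to compound 4 (0.02 log units; within the scatter) estimated to lie within the scatter. The estimate for compound 4 in this assay is 22 nM, with a range from 6 nM to 90 nM.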

Compound 4, half-maximal inhibitory concentration: 13 nM
Compound 4: the middle estimate sits 1.7-fold (0.23 log units) above what was measured; low and high end bracket the measured number.
By their numbers in this assay, from the lowest: compounds 4, 2 and 1 (each within the scatter of the next); then compound 3.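

In this assay, an aromatic ring on the amine nitrogen in the ring does not depend on the chain carbon among these compounds: with phenyl bound directly to that nitrogen, a 1.8-fold lower number from compound 1 to compound 4 (0.25 log units; within the scatter) and a 1.4-fold lower number from compound 2 to compound 4 (0.14 log units; within the scatter) both stay within the scatter, so compound 4 cannot be told apart from the two arylmethyl compounds. The same position is now also seen with phenyl set against the bare nitrogen, an 11-fold lower number from compound 3 to compound 4 (1.05 log units; beyond the scatter), so all three compounds with an aromatic ring on this nitrogen, with or without the chain carbon, stand apart from compound 3. Nothing on hand explains why these groups read alike or why the bare nitrogen gives a higher number.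

The compounds shown leave open whether an aromatic ring is needed here at all, since a saturated ring such as cyclohexyl or a small group such as methyl or acetyl would test that directly. They also leave open how far this position tolerates a longer chain, such as 2-phenylethyl, or a phenyl ring bearing a fluorine or a methoxy group.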